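From a Dichlorophenyl to a Bromofluorophenyl Arm

The source may report more compounds than this note shows. Statements on the series, on what has been measured and on what is new or still open speak of the compounds shown alone.

Compound 3 `C=CCn1c(=O)/c(=C\c2ccc(Cl)c(Cl)c2)[nH]c(=O)/c1=C\c1ccccc1OC` gives in a functional assay on MOLT-4 cells (Homo sapiens) for cytotoxicity, read by CCK-8 assay, with a stated time of 72 h (a higher number here means a weaker inhibitor, a lower number a stronger inhibitor), only the outcome "not active" (no number reported), so no number places it among its neighbours. Among the compounds with values here, its two relatives share the same core: compound 1 `C=CCn1c(=O)/c(=C\c2cccc(F)c2)[nH]c(=O)/c1=C\c1ccccc1OC` gives 6500 nM in this assay, and compound 2 `C=CCn1c(=O)/c(=C\c2cccc(Cl)c2Cl)[nH]c(=O)/c1=C\c1ccccc1OC` gives 1200 nM in this assay; the step of a 5.4-fold lower number from compound 1 to compound 2 (0.73 log units; beyond the scatter) is the only measured step available. Compound 4 `C=CCn1c(=O)/c(=C\c2cc(Br)ccc2F)[nH]c(=O)/c1=C\c1ccccc1OC` arises from compound 3 by the change (5-bromo-2-fluorophenyl in place of 3,4-dichlorophenyl on a double-bonded chain carbon bound to an aromatic carbon). Within the data shown here, no measured step bears directly on this change; the one step that exists shows only that exchanging one halogenated phenyl for another on that chain carbon can shift the number modestly. Because compound 3 gives "not active" (no number reported) while compound 2 gives 1200 nM, the halogenated phenyl variants span a wide spread, and compound 4 is expected to land somewhere within it rather than to define a new extreme. Compound 4 is therefore estimated at 5000 nM, with a range from 1000 nM to 30000 nM.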

Compound 4, half-maximal inhibitory concentration: 12900 nM
Compound 4: middle estimate off by 2.6-fold (0.41 log units), on the low side, within the range that was stated.
By their numbers in this assay, from the lowest: compound 2; then compounds 1 and 4 (each within the scatter of the next).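

In this assay, compound 4 returns a number where compound 3 returned none, so the step between them, like any other step involving compound 3, cannot be read. With the 5-bromo-2-fluorophenyl group on the double-bonded chain carbon, the data show an 11-fold higher number from compound 2 to compound 4 (1.03 log units; beyond the scatter) against the 2,3-dichlorophenyl group, which is a large change at this position. The same group gives a 2.0-fold higher number from compound 1 to compound 4 (0.30 log units; within the scatter) against the 3-fluorophenyl group, so compound 2 alone stands apart from the other two compounds with numbers.

On these data alone, it remains open whether a phenyl carrying an amine or a carboxylic acid in place of the halogens would keep a number in this assay. Nothing available explains why these halogenated phenyl groups differ.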